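The source may report more compounds than this note shows. Statements on the series, on what has been measured and on what is new or still open speak of the compounds shown alone.

In an assay on membranes from liver for displacement of a labelled ligand from Type-2 angiotensin II receptor (Rattus norvegicus) (a lower number here means a stronger inhibitor, a higher number a weaker inhibitor), compound 1 `CCCCS(=O)(=O)NS(=O)(=O)c1sc(CC(C)C)cc1-c1ccc(Cn2ccnc2)cc1` gives > 10000 nM, which is a limit of the assay rather than a number. Compound 2 `CCCCOC(=O)NS(=O)(=O)c1ccc(CC(C)C)cc1-c1ccc(Cn2ccnc2)cc1` likewise returns only the limit > 10000 nM. Compound 3 `CCCCOC(=O)NS(=O)(=O)c1ccc(CCCC)cc1-c1ccc(Cn2ccnc2)cc1` also stops at the limit > 10000 nM. Compound 3 therefore stands at the limit with no readable place among the values shown, and the step that the two limits leave unreadable from compound 2 to compound 3 cannot be sized because of the limit of > 10000 nM in this assay, at which 3 of the 3 values shown sit. Compound 4 `CCCCc1ccc(S(=O)(=O)NC(=O)OCC)c(-c2ccc(Cn3ccnc3)cc2)c1` differs from compound 3 by hydrogen in place of ethyl on a saturated chain carbon, two bonds along the chain from an oxygen next to a carbonyl group. Among the compounds with values here, no measured step bears on this change, and the single comparison at hand is unreadable, so nothing beyond another limit is expected in this assay. Compound 4 is expected to give about 20000 nM, within a range from 5000 nM to 100000 nM. The step that the limit leaves unreadable from compound 3 to compound 4 implied by this estimate is expected to be no step beyond the scatter.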

Compound 4, inhibition constant: > 10000 nM
Compound 4 ended at the assay's limit; the forecaster's own chance of this, stated with the estimate: 85%; the middle value does not contradict the limit.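

Compound 3 and compound 4 both stop at a limit in this assay, so no step between them can be read: the limit of > 10000 nM in this assay, at which 4 of the 4 values shown sit.

The compounds shown leave open how strong an inhibitor any of them is in this assay.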